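This account rests on a few compounds, and the source may have more. Where it says the series, first, only, none or still open, it means among the compounds named here.

Measured so far:
Compound 1, `COC(=O)[C@@H]1COC(/C=C/c2ccc(C)cc2)=N1`: 85.1%
Compound 2, `COC(=O)[C@@H]1COC(/C=C/c2ccccc2)=N1`: 68.6%
Compound 3, `COC(=O)c1coc(/C=C/c2ccc(C)cc2)n1`: 102%

All three were tested in an ADME assay on Vero cells (Chlorocebus sabaeus) for cytotoxicity, read by WST assay, tested at 50 ug/mL; on this read-out higher numbers stand for a weaker effect at the one concentration tested and lower numbers for a stronger effect. Compound 1 and compound 2 share one core and differ only by hydrogen in place of methyl on an aromatic carbon; this change gave a number 16.5 percentage points lower from compound 1 to compound 2 (beyond the scatter). Compound 3 is built on a second core; the difference between the two cores is not broken down here. Among the three, compound 3 gives the highest number, beyond the scatter from both others.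

Compound 4, `COC(=O)c1coc(/C=C/c2ccccc2)n1`, has not yet been measured. It differs from compound 3 by hydrogen in place of methyl on an aromatic carbon, the same structural change as that from compound 1 to compound 2. The expected step is a number 17 percentage points lower from compound 3 to compound 4 (beyond the scatter), resting on a number 16.5 percentage points lower from compound 1 to compound 2 (beyond the scatter). Compound 4 is therefore expected to give about 85%, most likely between 65% and 100%.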

Compound 4, a percentage reported as activity, at one concentration (the size of the read-out at that concentration, not a potency): 99.6%
The estimate for compound 4 lay 14.6 percentage points below the measured number, within the range that was stated.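

In this assay, hydrogen in place of methyl gave a number 2.4 percentage points lower from compound 3 to compound 4 (within the scatter), so the change did not carry over from one core to the other at the same size: the same change on two cores in this assay, a number 16.5 percentage points lower (beyond the scatter) from compound 1 to compound 2 and a number 2.4 percentage points lower (within the scatter) from compound 3 to compound 4, 14.1 percentage points apart, beyond the scatter of two such steps

A step seen on one core therefore cannot simply be added to a compound on the other core in this series. These two pairs show that the outcome depends on the core for this one change at one concentration, but they do not show why, or how any other change would carry over.

The compounds shown leave open how a chlorine atom or a methoxy group in place of the methyl would behave on each core. They also leave open what a carboxylic acid in place of the methyl ester would do.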